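The source may hold more compounds than are shown below. What is called first, only, known or untested is meant among the compounds shown, and "the series" means these compounds.

Compound 1 `COc1cc(C(=O)c2cn(-c3ccccc3)cc2-c2ccc(N)cc2)cc(OC)c1OC`: 9 nM
Compound 2 `COc1cc(C(=O)c2cn(-c3ccccc3Cl)cc2-c2ccccc2)cc(OC)c1OC`: 1800 nM

In a functional assay on MCF7 cells (Homo sapiens) for cytotoxicity, read by MTT assay, with a stated time of 96 h (a higher number here means a weaker inhibitor, a lower number a stronger inhibitor), compound 2 gives 1800 nM, the higher of the two numbers and well beyond the scatter from compound 1. Compound 3 `COc1cc(C(=O)c2cn(-c3ccccc3N)cc2-c2ccccc2)cc(OC)c1OC` has not yet been measured. It carries amino in place of chloro on an aromatic carbon, ortho to a large group: amino in place of chloro on an aromatic carbon. Among the measured compounds shown here, no measured pair shows this change alone, but amino also occurs in compound 1, at 9 nM. The expected step is a 7.2-fold lower number from compound 2 to compound 3 (0.86 log units; beyond the scatter), a moderate fall in the number, beyond the scatter. For compound 3 the estimated value is 250 nM, within an expected range of 30 nM to 1800 nM.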

Compound 3, half-maximal inhibitory concentration: 3800 nM
Compound 3: the middle estimate sits 15-fold (1.18 log units) below what was measured; the whole stated range lies below it.
By their numbers in this assay, from the lowest: compound 1; then compound 2; then compound 3.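

In this assay, amino in place of chloro at this position gives a 2.1-fold higher number from compound 2 to compound 3 (0.32 log units; beyond the scatter), so this change does not lower the number here. The low value of compound 1, which also carries amino, therefore does not extend to amino at this place, although compound 1 differs from compound 3 in more than one place and the two cannot be compared directly. Nothing available explains this result. Going by these compounds, whether a methoxy or a hydroxyl group at this place would give a lower number than chloro or amino remains open.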